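A few compounds are considered here, and "the series" means these few. Any claim that something is new, unique, unknown or untested is made for them only; others in the source may bear on it.

Measured so far:
compound 1, `Cc1cc(NC(=O)Nc2ccc(C(=O)O)cc2)c2ccccc2n1`: 9300 nM in a physicochemical assay for solubility, at pH 7.4; on this read-out higher numbers stand for higher solubility and lower numbers for lower solubility
compound 2, `Cc1cc(NC(=O)Nc2ccccc2C(F)(F)F)c2ccccc2n1`: 3800 nM in this assay

Of these two numbers, compound 2 stands lowest; its nearest neighbour is compound 1, whose number lies above it by a gap beyond the usual scatter of this assay. Compound 3, `Cc1cc(NC(=O)Nc2ccccc2F)c2ccccc2n1`, has not yet been measured. It differs from compound 2 in one place: fluoro in place of trifluoromethyl on an aromatic carbon. Going by the values given here, no pair of measured compounds shows a change of this kind, so there is no measured step to lean on; the expectation rests on compound 2 alone. The step from compound 2 to compound 3 is expected to be a modest rise in solubility, of about a 1.8-fold higher number from compound 2 to compound 3 (0.27 log units; within the scatter), and it may well stay within the scatter. Compound 3 is therefore estimated at 7000 nM in this assay, with a likely range from 2500 nM to 20000 nM.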

Compound 3, solubility: 3800 nM
The estimate for compound 3 lay 1.8-fold (0.27 log units) above the measured number, within the range that was stated.
By their numbers in this assay, from the lowest: compounds 2 and 3 (each within the scatter of the next); then compound 1.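

Replacing trifluoromethyl with fluoro on this aromatic carbon, ortho to a large group, gives no change at the digits printed from compound 2 to compound 3 (within the scatter) in this assay. Going by these compounds alone, this is the first reading of a single change at this position, and it shows that going from a group of 4 heavy atoms to one of 1 heavy atom leaves a difference that this read-out cannot separate from the scatter. Nothing available here accounts for this result.

On these data alone, whether this position is insensitive to other kinds of group remains open: an amine or a methoxy group on the same carbon could read quite differently from these two halogen-bearing groups. As far as these compounds go, it is also open whether the same replacement elsewhere on this ring would give a similar result.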